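Oxime ether chain length on the shared core

This account rests on a few compounds, and the source may have more. Where it says the series, first, only, none or still open, it means among the compounds named here.

Compound 1 `CO/N=C/c1cc(OC)c2c(c1OC)C(=O)C=CC2=O` carries a methyl on the oxime ether oxygen. In a functional assay on A549 cells (Homo sapiens) for antiproliferative activity (on this read-out higher numbers stand for an effect only at larger amounts of compound and lower numbers for an effect already at smaller amounts), compound 1 gives only a limit, > 10 ug/mL. Compound 2 `CCCCCO/N=C/c1cc(OC)c2c(c1OC)C(=O)C=CC2=O` extends this to pentyl. In this assay compound 2 likewise gives only a limit, > 10 ug/mL. Compound 3 `CCCCCCCCCCCCO/N=C/c1cc(OC)c2c(c1OC)C(=O)C=CC2=O` carries dodecyl. In this assay compound 3 also stands at a limit, > 10 ug/mL, so its position among the three is not a number. Compound 4 `CCCCCCCCCO/N=C/c1cc(OC)c2c(c1OC)C(=O)C=CC2=O` differs from compound 3 by hydrogen in place of propyl on a saturated chain carbon, nine bonds along the chain from an oxygen on an unsaturated carbon; cut one bond further out, the same difference reads butyl to methyl. The two measured steps along the chain, a step that the two limits leave unreadable from compound 1 to compound 2 and a step that the two limits leave unreadable from compound 2 to compound 3, bear on this change, and neither has a readable size because of the limit of > 10 ug/mL in this assay, at which 3 of the 3 values shown sit. For the measured compounds named here, no measured step therefore points in either direction, and no step beyond the scatter is expected in this assay. Compound 4 is expected to give 20 ug/mL, in the range 8 ug/mL to 100 ug/mL, most likely again reported as a limit. The step from compound 3 to compound 4 is estimated as a step that the limit leaves unreadable from compound 3 to compound 4.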

Compound 4, concentration for half-maximal effect: > 10 ug/mL
Compound 4: only a limit was reported; the forecaster's own chance of this, stated with the estimate: 85%; the middle value does not contradict the limit.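

In this assay, for the compounds shown here, compound 4 gives only a limit, > 10 ug/mL, so no step among compound 1, compound 2, compound 3 and compound 4 can be read: the limit of > 10 ug/mL in this assay, at which 4 of the 4 values shown sit. The compounds shown leave open how these four oxime ether chains compare in this assay.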